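From Ketone to Alcohol at the Tert-Butyl End

The compounds below may be only part of what the source reports. "The series", "measured", "known", "first", "only" and "open" are said of these compounds alone.

In a functional assay on MCF7 cells (Homo sapiens), read by MTT assay, with a stated time of 48 h (a lower number here means a stronger inhibitor, a higher number a weaker inhibitor), compound 1 `CCn1c(C(=O)NCCN)ccc1C(CC)(CC)c1ccc(OCC(O)C(C)(C)C)c(C)c1` gives 5.9 nM, while compound 2 `CC[C@@H](C)[C@H](NC(=O)c1ccc(C(CC)(CC)c2ccc(OCC(=O)C(C)(C)C)c(C)c2)n1CC)C(=O)O` gives 160 nM. Compound 2 therefore has the higher of the two numbers, and the gap lies beyond the usual scatter. Compound 3 `CC[C@@H](C)[C@H](NC(=O)c1ccc(C(CC)(CC)c2ccc(OCC(O)C(C)(C)C)c(C)c2)n1CC)C(=O)O` differs from compound 2 in one place: 1-hydroxy-2,2-dimethylpropyl in place of (tert-butyl)carbonyl on a saturated chain carbon bound to an oxygen on an aromatic ring. In words, 1-hydroxy-2,2-dimethylpropyl stands in place of (tert-butyl)carbonyl on a saturated chain carbon bound to an oxygen on an aromatic ring. Compound 1 already carries the 2-hydroxy-3,3-dimethylbutoxy group and gives 5.9 nM, but it also differs from compound 2 elsewhere, so the two values cannot isolate this change. A moderate fall in the number in this assay is expected, slightly beyond the scatter, and the estimated step is a 2.7-fold lower number from compound 2 to compound 3 (0.43 log units; beyond the scatter). For compound 3, the estimated value is 60 nM, with an expected range from 15 nM to 250 nM.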

Compound 3, half-maximal inhibitory concentration: 2000 nM
Compound 3: the middle estimate sits 33-fold (1.52 log units) below what was measured, and the stated range ends below it.
By their numbers in this assay, from the lowest: compound 1; then compound 2; then compound 3.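

At this place, on a saturated chain carbon bound to an oxygen on an aromatic ring, 1-hydroxy-2,2-dimethylpropyl in place of (tert-butyl)carbonyl gives a 13-fold higher number from compound 2 to compound 3 (1.10 log units; beyond the scatter) in this assay, so with the 1-carboxy-2-methylbutyl amide present the ketone is the better of the two groups. Compound 3 also allows the amide side to be read on its own: 1-carboxy-2-methylbutyl in place of 2-aminoethyl on an amide-type nitrogen gives a 340-fold higher number from compound 1 to compound 3 (2.53 log units; beyond the scatter), the larger of the two steps. Nothing available here explains either step.

On these data alone, whether the ketone would hold the same advantage with the 2-aminoethyl amide of compound 1 stays open. Also open, as far as these compounds go, is whether a methoxy group or an acetate ester in place of the hydroxyl would follow the alcohol or the ketone.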